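Nitrogen substituent changes and tolerated concentration

The compounds below may be only part of what the source reports. "The series", "measured", "known", "first", "only" and "open" are said of these compounds alone.

Among the measured compounds shown here, in an ADME assay on C8166 cells (Homo sapiens) for cytotoxicity, read by MTT assay (a higher number here means that more compound is tolerated, a lower number that less compound is tolerated), compound 3 (`Cc1ccc(Cn2cc(C(=O)O)c(=O)c3c(O)c(Cc4cccc(Cl)c4F)ccc32)cc1`) gives 256000 nM, the highest of the three numbers so far. Compound 1 (`CC(C)[C@@H](CO)n1cc(C(=O)O)c(=O)c2c(O)c(Cc3cccc(Cl)c3F)ccc21`) gives 125000 nM, and compound 2 (`O=C(O)c1cn(Cc2ccccc2)c2ccc(Cc3cccc(Cl)c3F)c(O)c2c1=O`) gives 20300 nM.

The next compound is compound 4 (`O=C(O)c1cn(Cc2ccc(F)c(F)c2)c2ccc(Cc3cccc(Cl)c3F)c(O)c2c1=O`), with 3,4-difluorophenyl in place of 4-methylphenyl on a saturated chain carbon bound to an aromatic nitrogen.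

The closest guide is a 13-fold higher number from compound 2 to compound 3 (1.10 log units; beyond the scatter), a large step for methyl in place of hydrogen on an aromatic carbon, and compound 4 has no such methyl. The modest steps of a 6.2-fold lower number from compound 1 to compound 2 (0.79 log units; beyond the scatter) and a 2.0-fold higher number from compound 1 to compound 3 (0.31 log units; beyond the scatter) show that the number in this assay can move either way with the group on the nitrogen. For the measured compounds named here, no measured compound carries 3,4-difluorophenyl, so the full size of the earlier methyl step is not assumed. A moderate fall is expected, with the estimate being a 4.3-fold lower number from compound 3 to compound 4 (0.63 log units; beyond the scatter). For compound 4 the expected value is 60000 nM, within an estimated range of 15000 nM to 200000 nM.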

Compound 4, half-maximal cytotoxic concentration: 71400 nM
Estimate against measurement, compound 4: 1.2-fold (0.08 log units) below, and the stated range covers the measured number.
By their numbers in this assay, from the lowest: compound 2; then compounds 4 and 1 (each within the scatter of the next); then compound 3.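

On the saturated chain carbon bound to an aromatic nitrogen, a substituted phenyl again gives a higher number than plain phenyl in this assay, with a 3.5-fold higher number from compound 2 to compound 4 (0.55 log units; beyond the scatter), so the rise seen with 4-methylphenyl is not confined to that one group among these compounds. The two substituted rings still differ, with a 3.6-fold lower number from compound 3 to compound 4 (0.55 log units; beyond the scatter), while 3,4-difluorobenzyl and the branched 1-(hydroxymethyl)-2-methylpropyl group cannot be separated here, with a 1.8-fold lower number from compound 1 to compound 4 (0.24 log units; within the scatter). Nothing available explains why the number moves with these groups.

Open, on these data alone, is whether a phenyl with a single fluorine would behave like 3,4-difluorophenyl, and whether a methoxy group or an amine on the ring would also give a higher number than plain phenyl. Also open, as far as these compounds go, is how a longer chain from the aromatic nitrogen to the ring would shift the number.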